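This account rests on a few compounds, and the source may have more. Where it says the series, first, only, none or still open, it means among the compounds named here.

Working notes on the series, read in a functional assay on A549 cells (Homo sapiens) for antiproliferative activity, read by MTT assay, with a stated time of 48 h; a lower number here means a stronger inhibitor of growth, a higher number a weaker inhibitor of growth. Compound 2 `CCOC(=O)N1N=C(c2cccc(O)c2)CC1c1cc(OC)c(OC)c(OC)c1` gives 5120 nM. Compound 3 `CCCOC(=O)N1N=C(c2cccc(O)c2)CC1c1cc(OC)c(OC)c(OC)c1` gives > 10000 nM, which is a limit and not a number. Compound 1 `COc1cc(C2CC(c3ccccc3)=NN2C(=O)OCc2ccccc2)cc(OC)c1OC` gives > 10000 nM, also a limit. Compound 3 therefore has no exact position in the series and stands at the limit of > 10000 nM in this assay, at which 2 of the 3 values shown sit.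

Compound 4 `COc1cc(C2CC(c3cccc(O)c3)=NN2C(=O)OCc2ccccc2)cc(OC)c1OC` differs from compound 3 by phenyl in place of ethyl on a saturated chain carbon bound to an oxygen next to a carbonyl group, which reads as propoxycarbonyl to benzyloxycarbonyl. For the measured compounds named here, the only measured step at this place is an at least 1.9-fold higher number from compound 2 to compound 3 (0.29 log units; that floor lies within the scatter). Its floor lies within the scatter, so it sets no firm size for a change on this chain. Compound 1 also carries benzyloxycarbonyl, but it gives only a limit, so it offers weak guidance. No step beyond the scatter is expected in this assay, and no direction is favoured with confidence. The estimated change is an at least 1.1-fold lower number from compound 3 to compound 4 (0.04 log units; that floor lies within the scatter), which is expected to stay within the scatter. A reading at the limit is quite likely. For compound 4 the expected value is 9000 nM, with an estimated range from 3000 nM to 25000 nM.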

Compound 4, concentration for 50% growth inhibition: > 10000 nM
Compound 4: no number, only a limit (the forecaster's own chance of this, stated with the estimate: 60%); middle value at least 1.1-fold (0.04 log units) from the limit.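

In this assay, for the compounds shown here, the ethoxycarbonyl of compound 2 gives way to benzyloxycarbonyl with the hydroxy group kept, a change read as an at least 1.9-fold higher number from compound 2 to compound 4 (0.29 log units; that floor lies within the scatter), so an aromatic ring on this chain gives no firmer step than the propoxycarbonyl of compound 3 did. The steps that join compound 4 to compound 3 and to compound 1 cannot be read, as both ends of each are limits, so the hydroxy group on an aromatic carbon does not bring the benzyloxycarbonyl compounds to a measured number in the range tested. Ethoxycarbonyl remains the only group at this place with a measured number, and the rest of the series gathers at one ceiling: the limit of > 10000 nM in this assay, at which 3 of the 4 values shown sit.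

Going by these compounds, how far compound 3 and compound 4 lie past that limit stays open, so no order can be given between propoxycarbonyl and benzyloxycarbonyl. Also open, on these data alone, is whether a methoxycarbonyl group, or an amine or a carboxylic acid on this chain, would give a lower number than ethoxycarbonyl does.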